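The compounds below may be only part of what the source reports. "The series", "measured", "known", "first", "only" and "open" are said of these compounds alone.

The study concerns four compounds built on a shared core. Compound 1 `CCCC[S+]([O-])c1nc2ccc(-c3cccs3)nc2s1` gives 1230 nM in an assay for inhibition of 15-hydroxyprostaglandin dehydrogenase [NAD(+)] (Homo sapiens), read by fluorescence, with a stated time of 15 min, in the presence of a further agent that is not named here; a higher number here means a weaker inhibitor, a lower number a stronger inhibitor. Compound 2 `CCCC[S+]([O-])c1sc2nc(-c3nccs3)cc(-c3ccc(CNS(C)(=O)=O)cc3)c2c1N` gives 4.6 nM in this assay, and compound 3 `Nc1c([S+]([O-])CCCF)sc2nc(-c3cccs3)cc(-c3ccccc3)c12` gives 6.1 nM in this assay. Among the three measured numbers, compound 2 has the lowest. Its nearest neighbour is compound 3, whose number sits within the usual scatter of it, so no order can be read between these two. Compound 1 stands far beyond the scatter on the weaker side.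

Compound 4 `CCCC[S+]([O-])c1sc2nc(-c3nccs3)cc(-c3ccc(CNC(=O)NCC)cc3)c2c1N` has not yet been measured in this assay. It differs from compound 2 in one place: ethylcarbamoyl in place of methylsulfonyl on an amine nitrogen. Within the data shown here, no pair of measured compounds differs in exactly this way, and the data therefore hold no measured step for this change. Compound 2 at 4.6 nM and compound 3 at 6.1 nM lie close together despite their other differences, which suggests that this part of the molecule tolerates variation. The expectation is that the change moves the number little, with no step beyond the scatter in either direction. Compound 4 is therefore estimated at 6 nM in this assay, within a range from 2 nM to 20 nM. The step this expectation implies is a 1.3-fold higher number from compound 2 to compound 4 (0.12 log units; within the scatter).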

Compound 4, half-maximal inhibitory concentration: 2.1 nM
The estimate for compound 4 lay 2.9-fold (0.46 log units) above the measured number, and the stated range covers the measured number.
By their numbers in this assay, from the lowest: compound 4; then compounds 2 and 3 (each within the scatter of the next); then compound 1.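

Among these compounds, replacing methylsulfonyl with ethylcarbamoyl on the amine nitrogen gives the first measured step at this position, and in this assay the result is a 2.2-fold lower number from compound 2 to compound 4 (0.34 log units; beyond the scatter) as a modest change that lies beyond the usual scatter. The group on this nitrogen, whose other neighbour is a saturated chain carbon, therefore has a readable influence on the number, and the methylsulfonyl group is not needed to keep it low, at least in this one pair. The change replaces a group with no hydrogen-bond donor by one with a hydrogen-bond donor, but the data hold no measurement that connects this or any other feature of the two groups to the step.

Going by these compounds, this single pair cannot separate the contributions of the entering group's parts, so it remains open whether a shorter or longer chain in place of the ethyl, such as methylcarbamoyl or propylcarbamoyl, would move the number further. On these data alone, it also remains open how an acetyl group or a free amine on the same nitrogen would compare, and whether the step would hold with other groups elsewhere on the shared core.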